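The source may report more compounds than this note shows. Statements on the series, on what has been measured and on what is new or still open speak of the compounds shown alone.

Three analogues sharing one core have been tested in an assay on NK92 cells for inhibition of interleukin-15 (Homo sapiens), read by AlphaScreen, with stated times of 30 min and 1 h; on this read-out lower numbers stand for stronger inhibition and higher numbers for weaker inhibition. Compound 1 `Cn1c(Cc2nn(C)c(=O)c3ccccc23)nnc1SCC(=O)Nc1ccc(Cl)cc1Cl` gives 4500 nM. Compound 2 `CCOC(CCn1c(Cc2nn(C)c(=O)c3ccccc23)nnc1SCCCCCCCC(=O)Nc1ccc(Cl)cc1Cl)OCC` gives 30000 nM, the highest of the two numbers recorded, and clearly apart from compound 1. Compound 3 `Cn1nc(Cc2nnc(SCC(=O)Nc3ccc(Cl)cc3Cl)n2CCC(=O)O)c2ccccc2c1=O` reaches only the limit of the assay, > 30000 nM. Compound 4 `Cn1nc(Cc2nnc(SCCCCCCCC(=O)Nc3ccc(Cl)cc3Cl)n2CCC(=O)O)c2ccccc2c1=O` has not yet been measured; it differs from compound 2 by carboxy in place of diethoxymethyl on a saturated chain carbon, two bonds along the chain from an aromatic nitrogen. Within the data shown here, the one measured step that bears on this change, an at least 6.6-fold higher number from compound 1 to compound 3 (0.82 log units; beyond the scatter), went toward weaker inhibition and ended at a limit, (the limit of > 30000 nM in this assay, at which 1 of the 3 values shown sits). The author therefore expects compound 4 to move further in that direction, by an estimated 2.0-fold higher number from compound 2 to compound 4 (0.30 log units; within the scatter), quite possibly beyond the reach of this assay. The estimate for compound 4 in this assay is 60000 nM, between 20000 nM and 200000 nM.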

Compound 4, half-maximal inhibitory concentration: 9500 nM
Beside the measured number, compound 4's estimate is 6.3-fold (0.80 log units) above it; measured number below the stated range.
By their numbers in this assay, from the lowest: compound 1; then compound 4; then compound 2.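

With the sulfur-linked chain of compound 2 kept in place in this assay, replacing 3,3-diethoxypropyl with 2-carboxyethyl gives a 3.2-fold lower number from compound 2 to compound 4 (0.50 log units; beyond the scatter), so carboxy at this position does not by itself weaken inhibition. The earlier step, an at least 6.6-fold higher number from compound 1 to compound 3 (0.82 log units; beyond the scatter), went the other way, so the direction of this change depends on the rest of the compound. That earlier step ends at a limit for compound 3: the limit of > 30000 nM in this assay, at which 1 of the 4 values shown sits.

On these data alone, whether an amine or a primary amide on the same chain would match the carboxylic acid of compound 4 remains open. So does whether a methyl ester there would behave like the acid or like the diethoxymethyl group.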